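A few compounds are considered here, and "the series" means these few. Any claim that something is new, unique, unknown or untested is made for them only; others in the source may bear on it.

Compound 2 `CCS(=O)(=O)N1CCC(CN(C2Cc3cc(C#N)ccc3N(Cc3cncn3C)C2)S(=O)(=O)c2ccccn2)CC1` gives 0.1 10^-6 cm/s in an ADME assay on Caco-2 cells (Homo sapiens) for permeability, in the apical to basolateral direction (on this read-out higher numbers stand for higher permeability and lower numbers for lower permeability), the lowest of the three numbers available. Compound 1 `Cn1cncc1CN1CC(N(CC2CCN(C(=O)C3CCCC3)CC2)S(=O)(=O)c2ccccn2)Cc2cc(C#N)ccc21` gives 0.5 10^-6 cm/s and compound 3 `Cn1cncc1CN1CC(N(CC2CCN(C(=O)N3CCCCC3)CC2)S(=O)(=O)c2ccccn2)Cc2cc(C#N)ccc21` gives 0.6 10^-6 cm/s; the steps were a 5.0-fold lower number from compound 1 to compound 2 (0.70 log units; beyond the scatter) and a 6.0-fold higher number from compound 2 to compound 3 (0.78 log units; beyond the scatter), while a 1.2-fold higher number from compound 1 to compound 3 (0.08 log units; within the scatter). Compound 4 `Cc1noc(C)c1CN(C1Cc2cc(C#N)ccc2N(Cc2cncn2C)C1)S(=O)(=O)c1ccccn1` differs from compound 2 by 3,5-dimethyl-1,2-oxazol-4-yl in place of 1-(ethylsulfonyl)piperidin-4-yl on a saturated chain carbon bound to a sulfonamide nitrogen. Neither measured step matches this change directly: both swap the group on the amine nitrogen in a ring, whereas here the whole 1-(ethylsulfonyl)piperidin-4-yl leaves. The two steps nonetheless place compound 2 at the low end, so a modest rise is expected, though with wide uncertainty. The number for compound 4 is estimated at 0.5 10^-6 cm/s, within 0.1 10^-6 cm/s to 2 10^-6 cm/s, an expected step of a 5.0-fold higher number from compound 2 to compound 4 (0.70 log units; beyond the scatter).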

Compound 4, apparent permeability: 8 10^-6 cm/s
Estimate against measurement, compound 4: 16-fold (1.20 log units) below, outside the stated range (above it).
By their numbers in this assay, from the lowest: compound 2; then compounds 1 and 3 (each within the scatter of the next); then compound 4.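

The change of 1-(ethylsulfonyl)piperidin-4-yl to 3,5-dimethyl-1,2-oxazol-4-yl on a saturated chain carbon bound to a sulfonamide nitrogen gives an 80-fold higher number from compound 2 to compound 4 (1.90 log units; beyond the scatter) in this assay, a larger step than either earlier change on the amine nitrogen in a ring. The hydrogen-bond acceptor count is the same in both groups, so that count does not separate them, while the ring and heavy-atom count do differ. Nothing measured here accounts for the step. Still open, from the compounds shown here alone, is whether a phenyl ring at this place would read like the 3,5-dimethyl-1,2-oxazol-4-yl, and how a piperidine with a free amine would read.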